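No Readable Cytotoxicity Signal Across a Pyridyl-to-Aryl Swap

A few compounds are considered here, and "the series" means these few. Any claim that something is new, unique, unknown or untested is made for them only; others in the source may bear on it.

Compound 1, `CC(C)N(Cc1cccc(OCCCCCC(=O)O)c1)C(=O)c1ccc(-c2ccncc2)cc1`. In an ADME assay on HepG2 cells (Homo sapiens) for cytotoxicity, read by CellTiter-Glo and resazurin assay, with a stated time of 72 h (a lower number here means that less compound is needed, a higher number that more compound is needed for the effect), compound 1 gives > 26000 nM, which is a limit of the assay and not a number.
Compound 2, `CC(C)N(Cc1cccc(OCCCCCC(=O)O)c1)C(=O)c1ccc(-c2cccc(Oc3ccccc3)c2)cc1`. In this assay compound 2 gives > 18700 nM, again a limit.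
Compound 3, `CCOC(=O)CCCCCOc1cccc(CN(C(=O)c2ccc(-c3ccncc3)cc2)C(C)C)c1`. In this assay compound 3 gives > 26000 nM, likewise a limit.

Compound 3 therefore stands only at a limit, and so do the other two values shown: they sit at the limit of > 26000 nM in this assay, at which 2 of the 3 values shown sit, and at the limit of > 18700 nM in this assay, at which 1 of the 3 values shown sits. Going by the values given here, the one measured step, a step that the two limits leave unreadable from compound 1 to compound 3, is unreadable for the same reason. Compound 4, `CCOC(=O)CCCCCOc1cccc(CN(C(=O)c2ccc(-c3cccc(OCC(C)C)c3)cc2)C(C)C)c1`, differs from compound 3 by 3-(isobutoxy)phenyl in place of pyridin-4-yl on an aromatic carbon. Among the compounds with values here, no measured step bears directly on this change. Compound 2 carries a large carbon-only aromatic group and reaches only a limit. Nothing in the numbers shown points to cytotoxicity appearing within the tested range, so the step from compound 3 to compound 4 is expected to be a number no higher from compound 3 to compound 4 (the limit leaves the size open), most likely another limit. Compound 4 is estimated at 26000 nM, within 10000 nM to 60000 nM.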

Compound 4, half-maximal effective concentration: > 26000 nM
Compound 4: a limit, no number; the forecaster's own chance of this, stated with the estimate: 80%; the middle value sits exactly at the limit.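

In this assay compound 4 gives > 26000 nM, a limit of the assay and not a number. Going by these compounds alone, compound 3 also stands at a limit, so no step between compound 3 and compound 4 can be read. The compounds shown leave open whether 3-(isobutoxy)phenyl in place of pyridin-4-yl changes the half-maximal effective concentration at all.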